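The source may report more compounds than this note shows. Statements on the series, on what has been measured and on what is new or still open speak of the compounds shown alone.

Values so far in a functional assay on HCT-116 cells (Homo sapiens), read by sulforhodamine B assay, with a stated time of 5 days; on this read-out higher numbers stand for weaker inhibition of growth and lower numbers for stronger inhibition of growth
- compound 1 `OC[C@H]1O[C@@H](n2cc(F)c3c(-c4ccoc4)ncnc32)[C@H](O)[C@@H]1O` gives 18 nM
- compound 2 `OC[C@H]1O[C@@H](n2cc(Cl)c3c(-c4cccs4)ncnc32)[C@H](O)[C@@H]1O` gives 270 nM

Compound 2, at 270 nM in this assay, holds the higher of the two numbers, and its gap to the other value lies beyond the scatter. The next compound is compound 3 `OC[C@H]1O[C@@H](n2cc(Cl)c3c(-c4ccoc4)ncnc32)[C@H](O)[C@@H]1O`, not yet measured. It differs from compound 2 by furan-3-yl in place of thiophen-2-yl on an aromatic carbon. Compound 1, which also carries furan-3-yl, reads 18 nM in this assay, and on that value a step towards stronger inhibition of growth, beyond the scatter, is expected. Within the data shown here, the expected size is a 6.0-fold lower number from compound 2 to compound 3 (0.78 log units; beyond the scatter), an uncertain estimate with only two values behind it. For compound 3 the estimated value is 45 nM, with an expected range from 12 nM to 170 nM.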

Compound 3, concentration for 50% growth inhibition: 2000 nM
Estimate against measurement, compound 3: 44-fold (1.65 log units) below; the measured number lies above the stated range.
By their numbers in this assay, from the lowest: compound 1; then compound 2; then compound 3.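

In this assay, furan-3-yl on this aromatic carbon, next to the ring nitrogen, does not improve on thiophen-2-yl when chloro is present: the exchange gives a 7.4-fold higher number from compound 2 to compound 3 (0.87 log units; beyond the scatter) and so weaker inhibition of growth. Among these compounds, with furan-3-yl held in place, the single exchange of fluoro for chloro gives a 110-fold higher number from compound 1 to compound 3 (2.05 log units; beyond the scatter) and shows that the low number of compound 1 does not carry over to its chloro counterpart, so a reading for furan-3-yl holds only with its halogen stated. Nothing available here explains either step.

Going by these compounds, whether thiophen-2-yl would also lose or gain on moving from chloro to fluoro stays open, so it cannot be said whether the two exchanges act independently. On these data alone, how an amine or a phenyl ring would read at this aromatic carbon is also open.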